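From dioxolanyl to (allyloxy)methyl: an expected tolerability

The source may hold more compounds than are shown below. What is called first, only, known or untested is meant among the compounds shown, and "the series" means these compounds.

Compound 1 `COC[C@H]1C[C@@](CC(C)C)(C(=O)O)N(C(=O)c2ccc(C(C)(C)C)c(OC)c2)[C@H]1[C@H]1COC(C)(C)O1` was examined in an ADME assay on Huh-5-2 cells (Homo sapiens) for cytotoxicity, with a stated time of 3 days; a higher number here means that more compound is tolerated, a lower number that less compound is tolerated. In this assay compound 1 gives only a limit, > 120000 nM. Two measured neighbours share its core. Compound 2 `COC[C@H]1C[C@@](CC(C)C)(C(=O)O)N(C(=O)c2ccc(C(C)(C)C)c(OC)c2)[C@H]1[C@H]1COC(=O)O1` carries 2-oxo-1,3-dioxolan-4-yl in place of 2,2-dimethyl-1,3-dioxolan-4-yl on a saturated ring carbon; in this assay compound 2 likewise gives only a limit, > 120000 nM. Compound 3 `COC[C@H]1C[C@@](CC(C)C)(C(=O)O)N(C(=O)c2ccc(C(C)(C)C)c(OC)c2)[C@H]1C(N)=O` carries carbamoyl in place of 2,2-dimethyl-1,3-dioxolan-4-yl on a saturated ring carbon; in this assay compound 3 also gives only a limit, > 120000 nM. The three steps between them, a step that the two limits leave unreadable from compound 1 to compound 2, a step that the two limits leave unreadable from compound 1 to compound 3 and a step that the two limits leave unreadable from compound 2 to compound 3, carry no readable size because of the limit of > 120000 nM in this assay, at which 3 of the 3 values shown sit.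

The unmeasured compound 4 `C=CCOC[C@H]1[C@@H](COC)C[C@@](CC(C)C)(C(=O)O)N1C(=O)c1ccc(C(C)(C)C)c(OC)c1` differs from compound 1 as follows: (allyloxy)methyl in place of 2,2-dimethyl-1,3-dioxolan-4-yl on a saturated ring carbon. Within the data shown here, none of the measured steps at this saturated ring carbon shows a readable size, so no movement beyond the scatter is expected, and compound 4 is expected to sit at the same limit, an expected step that the limit leaves unreadable from compound 1 to compound 4. Compound 4 is therefore estimated at 150000 nM, within a range from 80000 nM to 300000 nM.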

Compound 4, half-maximal cytotoxic concentration: > 120000 nM
Compound 4 gave a limit, no number; the forecaster's own chance of this, stated with the estimate: 85%; the middle value lies beyond the limit too.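

In this assay compound 4 also gives only a limit, so its steps from compound 1, compound 2 and compound 3 cannot be read, because all four compounds sit at the same limit: the limit of > 120000 nM in this assay, at which 4 of the 4 values shown sit.

The compounds shown leave open at what concentration any of them becomes cytotoxic, and whether the group on the saturated ring carbon changes that concentration.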